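Swapping a hydroxy group for an amino group

This account rests on a few compounds, and the source may have more. Where it says the series, first, only, none or still open, it means among the compounds named here.

Among the compounds with values here, in a functional assay on HeLa cells (Homo sapiens) for antiproliferative activity, read by MTT assay, with a stated time of 48 h (a lower number here means a stronger inhibitor, a higher number a weaker inhibitor), compound 3 `COc1ccc(-c2cc3c(cn2)[nH]c(=O)n3-c2cc(OC)c(OC)c(OC)c2)cc1O` gives 490 nM, the only real number so far. Compound 1 `COc1ccc(-c2cncc3[nH]c(=O)n(Cc4cc(OC)c(OC)c(OC)c4)c23)cc1O` reads > 20000 nM, which is a limit of the assay. Compound 2 `COc1ccc(-c2cncc3[nH]c(=O)n(Cc4cc(OC)c(OC)c(OC)c4)c23)cc1` reads > 20000 nM, which is also a limit. Compound 4 `COc1ccc(-c2cc3c(cn2)[nH]c(=O)n3-c2cc(OC)c(OC)c(OC)c2)cc1N` differs from compound 3 in one group: amino in place of hydroxy on an aromatic carbon. This puts amino in place of hydroxy on an aromatic carbon, ortho to a methoxy group. Within the data shown here, the only measured step involving a hydroxy group is a step that the two limits leave unreadable from compound 1 to compound 2, so it offers no size to carry over. With no firm direction to go on, the expected change, a 1.2-fold lower number from compound 3 to compound 4 (0.09 log units; within the scatter), stays within the usual scatter. Compound 4 is estimated at 400 nM, with an expected range of 90 nM to 2500 nM.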

Compound 4, half-maximal inhibitory concentration: 770 nM
Beside the measured number, compound 4's estimate is 1.9-fold (0.28 log units) below it; measured number inside the range.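

In this assay, amino in place of hydroxy on the 3-hydroxy-4-methoxyphenyl group gives a 1.6-fold higher number from compound 3 to compound 4 (0.20 log units; within the scatter), so the two groups cannot be told apart at this position. Within the data shown here, this is the first step here with a readable size. The earlier step at a hydroxy group cannot be read, because both of its values are limits of the assay: the limit of > 20000 nM in this assay, at which 2 of the 4 values shown sit.

Two groups at one position on one core say little about how much this position matters. From the compounds shown here alone, a carboxylic acid or a fluorine here, or plain hydrogen on the core of compound 3, remains open.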